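The source may report more compounds than this note shows. Statements on the series, on what has been measured and on what is new or still open speak of the compounds shown alone.

Measured so far in an ADME assay on Huh-7 cells (Homo sapiens) for cytotoxicity, with a stated time of 72 h (on this read-out higher numbers stand for lower toxicity in this test and lower numbers for higher toxicity in this test), and compared below
- Compound 1 `CS(=O)(=O)Nc1ccc2c(c1)S(=O)(=O)N=C(c1c(O)c(-c3cccs3)nn(CC3(C(F)(F)F)CCC3)c1=O)N2` gives > 1000 nM
- Compound 2 `CS(=O)(=O)Nc1ccc2c(c1)S(=O)(=O)N=C(c1c(O)c(-c3cccs3)nn(CCC3CCC3)c1=O)N2` gives > 1000 nM
- Compound 3 `CS(=O)(=O)Nc1ccc2c(c1)S(=O)(=O)N=C(c1c(O)c(-c3cccs3)nn(CCC3CCCC3)c1=O)N2` gives > 1000 nM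

Compound 3 stands at > 1000 nM and this is a limit of the assay, not a number. Compound 1 and compound 2 also carry limits, so the whole record is the limit of > 1000 nM in this assay, at which 3 of the 3 values shown sit, and no true value is known for any of them.

Compound 4 `CS(=O)(=O)Nc1ccc2c(c1)S(=O)(=O)N=C(c1c(O)c(-c3cccs3)nn(Cc3ccccc3)c1=O)N2` has not yet been measured. Its difference from compound 3 is phenyl in place of cyclopentylmethyl on a saturated chain carbon bound to an aromatic nitrogen and in words it is phenyl in place of cyclopentylmethyl on a saturated chain carbon bound to an aromatic nitrogen.

The measured steps bearing on this place are a step that the two limits leave unreadable from compound 1 to compound 2 and a step that the two limits leave unreadable from compound 1 to compound 3 and a step that the two limits leave unreadable from compound 2 to compound 3 and none of them has a size that can be carried over. Going by the values given here, none of the measured compounds has phenyl in this place. The expected step is a step that the limit leaves unreadable from compound 3 to compound 4 and no change beyond the scatter is expected in either direction. Compound 4 is estimated at 2000 nM with an expected range of 800 nM to 6000 nM and will most likely be reported as a limit too.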

Compound 4, half-maximal cytotoxic concentration: > 1000 nM
Compound 4: only a limit was reported; the forecaster's own chance of this, stated with the estimate: 85%; the middle value lies beyond the limit too.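

In this assay compound 4 gives > 1000 nM, which is a limit of the assay. No step from compound 1, compound 2 or compound 3 to compound 4 can be read, and the whole record stands at one limit: the limit of > 1000 nM in this assay, at which 4 of the 4 values shown sit.

The compounds shown leave open the true values of all four compounds and whether the group at this place changes them.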